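Adding a methoxy group to compound 3

This account rests on a few compounds, and the source may have more. Where it says the series, first, only, none or still open, it means among the compounds named here.

Measured in a functional assay on MCF7 cells (Homo sapiens) for antiproliferative activity, read by sulforhodamine B assay, with a stated time of 48 h; on this read-out lower numbers stand for stronger inhibition and higher numbers for weaker inhibition:
- compound 1 `COc1ccc(/C=C/C(=O)c2ccccc2-c2ccc(OC)c(OC)c2)cc1OC`: 4900 nM
- compound 2 `COc1ccc(/C=C/C(=O)c2ccccc2-c2ccc(F)cc2)cc1OC`: 240 nM
- compound 3 `COc1ccc(/C=C/C(=O)c2ccccc2-c2cccc(F)c2)cc1`: 640 nM

Not yet measured: compound 4 `COc1ccc(/C=C/C(=O)c2ccccc2-c2cccc(F)c2)cc1OC`.

Among the three numbers, compound 3 stands second highest. Compound 3 gives 640 nM and lies closer to compound 2 than to compound 1. The step to compound 4 is methoxy in place of hydrogen on an aromatic carbon, ortho to a methoxy group and meta to a large group.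

Within the data shown here, no measured step tests this change directly. Among the measured compounds shown here, the one available step, a 20-fold lower number from compound 1 to compound 2 (1.31 log units; beyond the scatter), is large, but it concerns 4-fluorophenyl in place of 3,4-dimethoxyphenyl, so it bears on the new compound only indirectly. Compound 2 already carries the methoxy group in question and gives 240 nM, a lower number than that of compound 3. Compound 1 carries it too and gives 4900 nM, a higher number than that of compound 3, so the two go against each other.

For the measured compounds named here, a slight lean towards a lower number is therefore expected, with no step clearly beyond the scatter. The expected step is a 1.5-fold lower number from compound 3 to compound 4 (0.18 log units; within the scatter). For compound 4 the estimated value is 420 nM, with an estimated range of 130 nM to 1300 nM.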

Compound 4, half-maximal inhibitory concentration: 1200 nM
The estimate for compound 4 lay 2.9-fold (0.46 log units) below the measured number, within the range that was stated.
By their numbers in this assay, from the lowest: compound 2; then compounds 3 and 4 (each within the scatter of the next); then compound 1.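

In this assay, among these compounds, methoxy in place of hydrogen on an aromatic carbon, ortho to a methoxy group and meta to a large group, gives a 1.9-fold higher number from compound 3 to compound 4 (0.27 log units; within the scatter) and so does not separate the two compounds at this position, which the earlier compounds could only address indirectly. With that methoxy group held constant, the steps beyond the scatter lie at the other site of change: 3-fluorophenyl in place of 4-fluorophenyl gives a 5.0-fold higher number from compound 2 to compound 4 (0.70 log units; beyond the scatter) and 3-fluorophenyl in place of 3,4-dimethoxyphenyl gives a 4.1-fold lower number from compound 1 to compound 4 (0.61 log units; beyond the scatter), so the wide spread among the methoxy-bearing compounds is tied to the aryl group and not to the methoxy group itself. No accompanying measurement accounts for any of these steps.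

Going by these compounds, whether a hydroxyl, an amine or a longer chain such as propoxy at this position would stay level with hydrogen and methoxy remains open. Also open is whether the methoxy step seen with 3-fluorophenyl carries over to the 4-fluorophenyl or 3,4-dimethoxyphenyl compounds, since neither has its counterpart with hydrogen at this position among the compounds shown.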